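Moving the chlorine on the thiourea aryl ring

The compounds below may be only part of what the source reports. "The series", "measured", "known", "first", "only" and "open" are said of these compounds alone.

Measured so far:
- compound 1, `COc1cc2c(cc1OC)C(=O)C(CC1CCN(C(=S)Nc3cccc([N+](=O)[O-])c3)CC1)C2`: "not determined" (no result reported) in a functional assay on the whole organism (strain Swiss albino) with Mus musculus as the target, with a stated time of 0.5 h; a lower number here means that less compound is needed, a higher number that more compound is needed for the effect
- compound 2, `COc1cc2c(cc1OC)C(=O)C(CC1CCN(C(=S)Nc3ccc([N+](=O)[O-])cc3)CC1)C2`: 100 mg/kg
- compound 3, `COc1cc2c(cc1OC)C(=O)C(CC1CCN(C(=S)Nc3ccccc3Cl)CC1)C2`: 300 mg/kg

The three compounds share one core and differ only in the aromatic ring attached to the thiourea nitrogen. Compound 1 carries a 3-nitrophenyl group there and has no reported number. Compound 2 carries a 4-nitrophenyl group and gives 100 mg/kg in this assay. For the measured compounds named here, compound 3 carries a 2-chlorophenyl group and gives 300 mg/kg, which is the highest of the two numbers known; the step of a 3.0-fold higher number from compound 2 to compound 3 (0.48 log units; beyond the scatter) is modest but beyond the scatter.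

Compound 4, `COc1cc2c(cc1OC)C(=O)C(CC1CCN(C(=S)Nc3ccc(Cl)cc3)CC1)C2`, is the next case. Its difference from compound 3 is 4-chlorophenyl in place of 2-chlorophenyl on an amide-type nitrogen. Going by the values given here, no measured step isolates this change: the step from compound 2 to compound 3 swaps both the substituent and its position at once, so it bears on the new compound only loosely. The one hint is that the 4-substituted compound 2 gave the lower number, so a small move downward is expected for compound 4, though a result within the scatter of compound 3 is just as plausible. The expected step of a 1.5-fold lower number from compound 3 to compound 4 (0.18 log units; within the scatter) is small. Compound 4 is estimated at 200 mg/kg with a range from 70 mg/kg to 500 mg/kg in this assay.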

Compound 4, minimum effective dose: 100 mg/kg
Compound 4: middle estimate off by 2.0-fold (0.30 log units), on the high side, within the range that was stated.
By their numbers in this assay, from the lowest: compounds 2 and 4 (each within the scatter of the next); then compound 3.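

Within this assay, moving the chlorine while keeping everything else the same gives a 3.0-fold lower number from compound 3 to compound 4 (0.48 log units; beyond the scatter) and so provides the first clean look at this position, showing that the place of the substituent on the ring attached to the thiourea nitrogen can by itself shift the minimum effective dose beyond the scatter. Replacing nitro with chloro on the same aromatic carbon gives no change at the digits printed from compound 2 to compound 4 (within the scatter) in this comparison, so for this pair the identity of the group does not separate the two compounds, whereas the chlorine's place does separate compound 3 and compound 4. Nothing available explains why the place of the chlorine matters in this whole-animal read-out.

Compound 1 gives "not determined" (no result reported), so steps involving the 3-nitrophenyl compound cannot be read, and the series offers no measured case of a substituent at that place on the ring. From the compounds shown here alone, it also remains open how a 3-chlorophenyl, an unsubstituted phenyl or a 4-methoxyphenyl group on the same nitrogen would compare, and so whether the gap between the 2-chlorophenyl and 4-chlorophenyl compounds extends to other groups.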